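The source may report more compounds than this note shows. Statements on the series, on what has been measured and on what is new or still open speak of the compounds shown alone.

Measured so far in a functional assay on PC-3 cells (Homo sapiens) for inhibition, read by sulforhodamine B assay, with a stated time of 48 h, tested at 0.1 uM; on this read-out lower numbers stand for a stronger effect and higher numbers for a weaker effect at the one concentration tested:
- compound 1, `COc1cc(Cl)cc(-c2nn(-c3cccc(NC(=O)Nc4ccc(Cl)c(C(F)(F)F)c4)c3)cc2-c2ccncc2)c1`, gives 91%
- compound 2, `COc1cc(Cl)cc(-c2nn(-c3cccc(NC(=O)Nc4ccc(Cl)c(Cl)c4)c3)cc2-c2ccncc2)c1`, gives 98%
- compound 3, `COc1cc(Cl)cc(-c2nn(-c3cccc(NC(=O)Nc4cccc(C(F)(F)F)c4)c3)cc2-c2ccncc2)c1`, gives 57%

On these numbers compound 3 stands lowest, which in this assay means the strongest effect of the three: the step of a number 34 percentage points lower from compound 1 to compound 3 (beyond the scatter) and the step of a number 41 percentage points lower from compound 2 to compound 3 (beyond the scatter) both lie beyond the scatter, whereas a number 7 percentage points higher from compound 1 to compound 2 (within the scatter) does not. Compound 4, `COc1cc(Cl)cc(-c2nn(-c3cccc(NC(=O)c4cccc(C(F)(F)F)c4)c3)cc2-c2ccncc2)c1`, is the unmeasured partner of compound 3. The change is: 3-(trifluoromethyl)phenyl in place of (3-(trifluoromethyl)phenyl)amino on a carbonyl carbon. The hydrogen-bond donor of the linker is thus lost and the ring sits directly on the carbonyl carbon. Going by the values given here, none of the measured steps touches this part of the molecule; each of them changes a group on an aromatic ring or exchanges one such ring for another, and none alters the carbonyl carbon or the amide-type nitrogen. There is therefore no measured guide to the size or direction of the step, and the expectation must stay wide. A moderate move toward a higher number, that is a weaker effect, is expected: a number 18 percentage points higher from compound 3 to compound 4 (beyond the scatter). Compound 4 is estimated at 75%, with a range from 50% to 100%.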

Compound 4, a percentage reported as activity, at one concentration (the size of the read-out at that concentration, not a potency): 52%
Compound 4: the middle estimate sits 23 percentage points above what was measured; the measured number falls inside the stated range.
By their numbers in this assay, from the lowest: compounds 4 and 3 (each within the scatter of the next); then compounds 1 and 2 (each within the scatter of the next).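

In this assay, setting the 3-(trifluoromethyl)phenyl ring directly on the carbonyl carbon gives a number 5 percentage points lower from compound 3 to compound 4 (within the scatter) and so shows that, in this pair, the linker can lose its amide hydrogen without a change that stands out from the scatter. The larger exchanges give a number 46 percentage points lower from compound 2 to compound 4 (beyond the scatter) and a number 39 percentage points lower from compound 1 to compound 4 (beyond the scatter) and place compound 4 with compound 3, apart from the two compounds that carry a chloro group on this ring. Nothing measured here bears on the reason for these results.

Still open, from the compounds shown here alone, is whether the 4-chloro-3-(trifluoromethyl)phenyl group, set directly on the carbonyl carbon, would keep the number of compound 4. The compounds shown also leave open how a longer chain, such as a methylene group, would behave when placed on the carbonyl carbon in place of the amino link.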